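The source may report more compounds than this note shows. Statements on the series, on what has been measured and on what is new or still open speak of the compounds shown alone.

Series notes. Compound 1 `O=C(CC1c2ccccc2N=C(SCCCCCN2CCCC2)N1c1ccc(-c2ccccc2)cc1)NCc1ccc(F)cc1` gives 51.5% in an assay on cells for inhibition of Voltage-dependent T-type calcium channel subunit alpha-1G (Homo sapiens), read by patch clamp, tested at 10 uM; a lower number here means less inhibition, a higher number more inhibition at the concentration tested (going by the name of the read-out); compound 2 `O=C(CC1c2ccccc2N=C(SCCCCCN2CCCC2)N1c1ccccc1)NCc1ccc(F)cc1` gives 60.1%; compound 3 `CN(C)CCCCCSC1=Nc2ccccc2C(CC(=O)NCc2ccc(F)cc2)N1c1ccc(-c2ccccc2)cc1` gives 31%, the lowest of the three numbers, with compound 1 nearest and compound 2 furthest. Compound 4 `CN(C)CCCCCSC1=Nc2ccccc2C(CC(=O)NCc2ccc(F)cc2)N1c1ccccc1` is not yet measured. It differs from compound 3 by hydrogen in place of phenyl on an aromatic carbon. The same change has been measured once: a number 8.6 percentage points higher from compound 1 to compound 2 (within the scatter), a step that stayed within the scatter. The other measured step, a number 20.5 percentage points lower from compound 1 to compound 3 (beyond the scatter), concerns a different change and only sets the starting level. On this basis no step beyond the scatter is expected in this assay. The expected step is a number 5 percentage points higher from compound 3 to compound 4 (within the scatter). Compound 4 is therefore estimated at 36%, with a range of 20% to 52%.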

Compound 4, a percentage reported as inhibition, at one concentration (the size of the read-out at that concentration, not a potency): 26.7%
Compound 4: the middle estimate sits 9.3 percentage points above what was measured; the range from low to high includes it.
By their numbers in this assay, from the lowest: compounds 4 and 3 (each within the scatter of the next); then compounds 1 and 2 (each within the scatter of the next).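

In this assay the change from 4-phenylphenyl to hydrogen-ended phenyl gives a number 4.3 percentage points lower from compound 3 to compound 4 (within the scatter) with dimethylamino at the chain end, so this change stays within the scatter with either amine: the same change on two cores in this assay, a number 8.6 percentage points higher (within the scatter) from compound 1 to compound 2 and a number 4.3 percentage points lower (within the scatter) from compound 3 to compound 4, 12.9 percentage points apart, within the scatter of two such steps.
Among the compounds shown here, the change from pyrrolidin-1-yl to dimethylamino, earlier seen only with 4-phenylphenyl, gives a number 33.4 percentage points lower from compound 2 to compound 4 (beyond the scatter) with phenyl, and its size agrees across both cores: the same change on two cores in this assay, a number 20.5 percentage points lower (beyond the scatter) from compound 1 to compound 3 and a number 33.4 percentage points lower (beyond the scatter) from compound 2 to compound 4, 12.9 percentage points apart, within the scatter of two such steps.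
Among these four compounds, the larger differences therefore follow the chain-end amine, not the outer phenyl.
Open, going by these compounds, is how a chlorine or a methoxy group on that aromatic carbon would read.
Also open, on these data alone, is whether a piperidine at the chain end or a shorter chain would follow the pyrrolidin-1-yl or the dimethylamino compounds.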